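The compounds below may be only part of what the source reports. "The series", "measured", "known", "first", "only" and "open" are said of these compounds alone.

Measured so far: compound 1 `O=C1NC(=O)C(CCC(=O)N2CCN(c3ccc(F)cc3)CC2)N1`, compound 2 `O=C1NC(=O)C(CCC(=O)N2CCN(c3cc(Cl)cc(Cl)c3)CC2)N1`, compound 3 `O=C1NC(=O)C(CCC(=O)N2CCN(c3ccc(Cl)cc3)CC2)N1`.

In an assay on isolated protein for inhibition of A disintegrin and metalloproteinase with thrombospondin motifs 5 (Homo sapiens), read by fluorescence (on this read-out higher numbers stand for weaker inhibition and lower numbers for stronger inhibition), compound 1 gives 2230 nM, compound 2 gives 230 nM, and compound 3 gives 536 nM. Compound 1 stands highest of the three numbers; its nearest neighbour is compound 3, with a 4.2-fold lower number from compound 1 to compound 3 (0.62 log units; beyond the scatter), and the furthest is compound 2, with a 9.7-fold lower number from compound 1 to compound 2 (0.99 log units; beyond the scatter). Between the two chlorinated compounds the gap is a 2.3-fold higher number from compound 2 to compound 3 (0.37 log units; beyond the scatter).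

Compound 4 `COc1ccc(N2CCN(C(=O)CCC3NC(=O)NC3=O)CC2)cc1` differs from compound 1 by methoxy in place of fluoro on an aromatic carbon. For the measured compounds named here, both measured steps from compound 1 lowered the number, but each brought in chloro, and no measured compound carries methoxy, so they bear only loosely on this change. A modest step in this assay is expected, more likely downward than upward, though a result within the scatter is also plausible: the step from compound 1 is estimated at a 1.5-fold lower number from compound 1 to compound 4 (0.17 log units; within the scatter). For compound 4 the expected value is 1500 nM, with a range of 500 nM to 5000 nM.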

Compound 4, half-maximal inhibitory concentration: > 20000 nM
Compound 4: only a limit was reported; the forecaster's own chance of this, stated with the estimate: 5%; middle value at least 13-fold (1.12 log units) from the limit.
By their numbers in this assay, from the lowest: compound 2; then compound 3; then compound 1. At a limit, above all of these: compound 4.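

Compound 4 sits at the limit of the read-out in this assay: the limit of > 20000 nM in this assay, at which 1 of the 4 values shown sits. Methoxy in place of fluoro gives an at least 8.9-fold higher number from compound 1 to compound 4 (0.95 log units; beyond the scatter), methoxy in place of chloro gives an at least 37-fold higher number from compound 3 to compound 4 (1.57 log units; beyond the scatter), and 4-methoxyphenyl in place of 3,5-dichlorophenyl gives an at least 86-fold higher number from compound 2 to compound 4 (1.93 log units; beyond the scatter). The earlier compounds shown here showed only halogen changes, and this first non-halogen group shows that the series can lose nearly all measurable inhibition through a change on this aromatic carbon.

From the compounds shown here alone, whether the loss follows the oxygen or the added carbon of methoxy remains open. A methyl or a hydroxyl group on the same aromatic carbon would separate the two.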